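Chlorine on an Aromatic Ring and Tolerated Concentration

A few compounds are considered here, and "the series" means these few. Any claim that something is new, unique, unknown or untested is made for them only; others in the source may bear on it.

Compound 1, `N#Cc1ccc2c(Oc3ccccc3OCCn3ccc(=O)[nH]c3=O)cc(Cl)cc2c1`: 24000 nM
Compound 2, `N#C/C=C/c1cc(Cl)cc(Oc2ccccc2OCCn2ccc(=O)[nH]c2=O)c1`: 18000 nM
Compound 3, `N#Cc1ccc2c(Oc3ccccc3OCCn3ccc(=O)[nH]c3=O)cccc2c1`: > 100000 nM

All three were tested in an ADME assay on MT2 cells (Homo sapiens) for cytotoxicity, read by MTT assay; a higher number here means that more compound is tolerated, a lower number that less compound is tolerated. For compound 3 the reading is the limit of > 100000 nM in this assay, at which 1 of the 3 values shown sits, a limit of the assay and not a number. Among the compounds with values here, from compound 3 to compound 1 the one change is chloro in place of hydrogen on an aromatic carbon, and it made an at least 4.1-fold lower number from compound 3 to compound 1 (0.61 log units; beyond the scatter). Compound 4, `N#C/C=C/c1cc(Cl)cc(Oc2ccc(Cl)cc2OCCn2ccc(=O)[nH]c2=O)c1`, is not yet measured; it differs from compound 2 by chloro in place of hydrogen on an aromatic carbon. This is the same kind of change, though the place differs: in compound 1 the ring is part of a fused or bridged system of two rings, meta and para to a fused ring, whereas in compound 4 it is a six-membered ring of carbon only. The difference between the cores of compound 2 and compound 3 is not broken down here. Compound 4 is expected to show a lower number than compound 2, about a 2.0-fold lower number from compound 2 to compound 4 (0.30 log units; within the scatter), resting on an at least 4.1-fold lower number from compound 3 to compound 1 (0.61 log units; beyond the scatter). The estimate for compound 4 is 9000 nM, between 3000 nM and 25000 nM.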

Compound 4, half-maximal cytotoxic concentration: 10000 nM
Compound 4: middle estimate off by 1.1-fold (0.05 log units), on the low side; measured number inside the range.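

In this assay, chloro in place of hydrogen on an aromatic carbon gives a 1.8-fold lower number from compound 2 to compound 4 (0.26 log units; within the scatter), so on this core the step cannot be told apart from the ordinary spread of repeated measurements. Carrying the change from one core to another therefore fits the earlier direction without confirming it, and the data do not show that the two cores respond either alike or differently: the same change on two cores in this assay, an at least 4.1-fold lower number (0.61 log units; beyond the scatter) from compound 3 to compound 1 and a 1.8-fold lower number (0.26 log units; within the scatter) from compound 2 to compound 4; the limit leaves it open whether they differ The earlier comparison starts from a limit of the assay and not a number: the limit of > 100000 nM in this assay, at which 1 of the 4 values shown sits.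

Going by these compounds, whether a fluoro, methyl or methoxy group on the same aromatic carbon would give a step like that of chloro remains open. So does how chloro would behave on a core other than these.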